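Mirror Image of a Low-Inhibition Sulfonamide

The source may report more compounds than this note shows. Statements on the series, on what has been measured and on what is new or still open speak of the compounds shown alone.

Compound 2, `Cc1cc(F)c(F)cc1NC[C@@H]1[C@@H](c2ccc(S(N)(=O)=O)cc2)C1(C)C`, is the higher of the two numbers measured here: in a functional assay on the whole organism with Mus musculus as the target, with stated times of 60 min and 30 min, at a dose of 1 mg/kg by the oral route (on this read-out higher numbers stand for more inhibition at the one dose given (going by the name of the read-out) and lower numbers for less inhibition), compound 2 gives 8%. Among the compounds with values here, its only comparator is compound 1, `Cc1ccc(F)cc1NC[C@@H]1[C@@H](c2ccc(S(N)(=O)=O)cc2)C1(C)C`, for which compound 1 gives -9%. Within the data shown here, the one measured step, a number 17 percentage points higher from compound 1 to compound 2 (beyond the scatter), added a fluoro in place of hydrogen on an aromatic carbon and lifted inhibition modestly.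

Compound 3, `Cc1cc(F)c(F)cc1NC[C@H]1[C@H](c2ccc(S(N)(=O)=O)cc2)C1(C)C`, keeps every atom and bond of compound 2 and differs only in how the two ring stereocentres are drawn: the two compounds have the same atoms and bonds and differ only in configuration as drawn: 2 of 2 stereo elements differ (all stereocentres are inverted: mirror images); a stereocentre at a saturated ring carbon is drawn R in compound 2 and S in compound 3; a stereocentre at a saturated ring carbon is drawn R in compound 2 and S in compound 3. Among the measured compounds shown here, no measured step involves a change of configuration, so the step from compound 1 to compound 2 offers no direct guidance on what a mirror image does in this assay. Both measured numbers sit close to zero, so a large move in either direction seems unlikely.

For compound 3 a value of 0% is expected, within -15% to 18%, which means an estimated step of a number 8 percentage points lower from compound 2 to compound 3 (within the scatter), not beyond the scatter.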

Compound 3, a percentage reported as inhibition, in the whole organism at one dose (the size of the read-out at that dose, not a potency): -13%
For compound 3 the middle estimate is 13 percentage points above the measured one; low and high end bracket the measured number.
By their numbers in this assay, from the lowest: compounds 3 and 1 (each within the scatter of the next); then compound 2.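

Configuration at the two ring stereocentres counts in this assay: inverting both gives a number 21 percentage points lower from compound 2 to compound 3 (beyond the scatter), a modest step. The earlier step changed only a fluoro on an aromatic carbon, so it said nothing about these two stereocentres. This shift can be assigned to configuration alone, because no atom or bond changes between the mirror images: the fact that compounds 2 and 3 differ only in the configuration as drawn

Only one mirror-image pair is shown, so it remains open whether the drawn configuration of compound 2 would keep its edge with a different group on the shared core, such as a carboxylic acid in place of the sulfonamide or a nitrile in place of a fluoro. On these data alone, what inverting just one of the two stereocentres would do also remains open.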